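This account rests on a few compounds, and the source may have more. Where it says the series, first, only, none or still open, it means among the compounds named here.

Measured so far: compound 1 `COc1ccc(C2N=C(SCc3ccccc3Cl)NC(C)=C2C(=O)Nc2ccc(F)cc2)cc1OC` and compound 2 `CC1=C(C(=O)Nc2ccc(F)cc2)C(c2ccc([N+](=O)[O-])cc2)N=C(SCc2ccccc2Cl)N1`.

In a functional assay on the whole organism (artery, strain albino) with Rattus norvegicus as the target, with a stated time of 60 min, at a dose of 10 mg/kg by the oral route (on this read-out higher numbers stand for more inhibition at the one dose given (going by the name of the read-out) and lower numbers for less inhibition), compound 1 gives 11.8%. In this assay compound 2 gives 6.2%. Compound 2 stands at the bottom of the two numbers, yet a number 5.6 percentage points lower from compound 1 to compound 2 (within the scatter) lies within the scatter, so the two are not separated. Compound 3 `CC1=C(C(=O)Nc2ccc(F)cc2)C(c2ccc([N+](=O)[O-])cc2)N=C(SCc2ccc(F)cc2)N1` is not yet measured; it differs from compound 2 by 4-fluorophenyl in place of 2-chlorophenyl on a saturated chain carbon bound to a sulfur. Among the compounds with values here, no measured step touches this position: the one known step concerns a different part of the core and is small. Compound 3 is therefore expected to show a number 1.8 percentage points higher from compound 2 to compound 3 (within the scatter) in this assay, nothing beyond the scatter. Compound 3 is estimated at 8%, range 0% to 25%.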

Compound 3, a percentage reported as inhibition, in the whole organism at one dose (the size of the read-out at that dose, not a potency): 10.8%
Compound 3: the middle estimate sits 2.8 percentage points below what was measured, and the stated range covers the measured number.
By their numbers in this assay, from the lowest: compounds 2, 3 and 1 (each within the scatter of the next).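

The position on a saturated chain carbon bound to a sulfur now has its first reading: in this assay the exchange of 2-chlorophenyl for 4-fluorophenyl gives a number 4.6 percentage points higher from compound 2 to compound 3 (within the scatter) and so does not separate the two compounds. With 4-nitrophenyl held in place, these two groups cannot be told apart at this dose. Nothing available bears on why this exchange reads as it does.

Still open, going by these compounds, is how an amine, a carboxylic acid or a longer chain would read in place of the 4-fluorobenzyl. Also open, on these data alone, is whether this exchange would read the same with 3,4-dimethoxyphenyl on the saturated ring carbon.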